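Adding a Fluoro to Compound 3: Expecting Compound 4

The source may hold more compounds than are shown below. What is called first, only, known or untested is meant among the compounds shown, and "the series" means these compounds.

Of the compounds shown here, three that share one core have been measured in a functional assay on RAW264.7 cells (Mus musculus), with a stated time of 3 days; a lower number here means a stronger inhibitor, a higher number a weaker inhibitor. Compound 3 `COc1cnc(-c2ccccn2)nc1NCc1ccccc1F` gives 130 nM in this assay. Compound 1 `COc1cnc(-c2ccccn2)nc1NCc1ccccc1C` gives 220 nM, and the gap between the two is a 1.7-fold lower number from compound 1 to compound 3 (0.23 log units; within the scatter), so neither stands apart from the other. Compound 2 `COc1cnc(-c2ccccn2)nc1NCCCC(=O)O` yields only a limit of the assay, > 10000 nM, and no number is known for it. That limit is the limit of > 10000 nM in this assay, at which 1 of the 3 values shown sits. The two large steps, an at least 45-fold higher number from compound 1 to compound 2 (1.65 log units; beyond the scatter) and an at least 76-fold lower number from compound 2 to compound 3 (1.88 log units; beyond the scatter), each exchange the whole group on the saturated chain carbon bound to a nitrogen on the aromatic ring.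

Compound 4 `COc1cnc(-c2ccccn2)nc1NCc1ccc(F)cc1F` has not yet been measured. It differs from compound 3 by fluoro in place of hydrogen on an aromatic carbon. The measured step that most resembles this one is a 1.7-fold lower number from compound 1 to compound 3 (0.23 log units; within the scatter), which also changes a single group on an aromatic carbon of that ring and stays within the scatter. The large steps swap the ring for a chain and say little about one added fluoro. A small step is therefore expected: compound 4 is estimated at 130 nM, between 50 nM and 350 nM. The expected change is no change at the digits printed from compound 3 to compound 4 (within the scatter), not beyond the scatter.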

Compound 4, half-maximal inhibitory concentration: 110 nM
Estimate against measurement, compound 4: 1.2-fold (0.07 log units) above; the range from low to high includes it.
By their numbers in this assay, from the lowest: compounds 4, 3 and 1 (each within the scatter of the next). At a limit, above all of these: compound 2.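

In this assay, for the compounds shown here, the earlier compounds only exchanged a group already present on the ring, whereas compound 4 puts a fluoro on a ring carbon that carried hydrogen, para to a large group and meta to the first fluoro, and the result, a 1.2-fold lower number from compound 3 to compound 4 (0.07 log units; within the scatter), shows that this carbon can take a fluoro without a shift beyond the scatter. The wider exchange of 2-methylphenyl for 2,4-difluorophenyl, a 2.0-fold lower number from compound 1 to compound 4 (0.30 log units; within the scatter), also stays within the scatter, so all three compounds with a substituted phenyl ring remain indistinguishable in this assay. With 2-carboxyethyl in place of the ring, the step remains large, an at least 90-fold lower number from compound 2 to compound 4 (1.95 log units; beyond the scatter), but it rests on a limit of the assay and not on a number: the limit of > 10000 nM in this assay, at which 1 of the 4 values shown sits.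

As far as these compounds go, a single fluoro is a very small probe, so it remains open whether a chloro, a methoxy or an amine on the same ring carbon would leave the number within the scatter. From the compounds shown here alone, it is also open whether compound 2 loses its activity through the missing ring or through its carboxylic acid, a question that a plain alkyl chain without the acid could address.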